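The source may report more compounds than this note shows. Statements on the series, on what has been measured and on what is new or still open speak of the compounds shown alone.

Measured so far in a functional assay on HEK293 cells for positive allosteric modulation of metabotropic glutamate receptor 5 (Rattus norvegicus), read by fluorescence and calcium flux; on this read-out lower numbers stand for smaller maximal responses and higher numbers for larger maximal responses:
Compound 1 `C[C@@H](NC(=O)c1ccc(C#Cc2cccc(F)c2)cn1)C(C)(C)C`: 66%
Compound 2 `CC(C)CNC(=O)c1ccc(C#Cc2cccc(F)c2)cn1`: 58.2%
Compound 3 `CC(C)(CO)NC(=O)c1ccc(C#Cc2cccc(F)c2)cn1`: 60.9%

Compound 3 stands second highest of the three numbers; the gap a number 2.7 percentage points higher from compound 2 to compound 3 (within the scatter) is the smaller one, the gap a number 5.1 percentage points lower from compound 1 to compound 3 (within the scatter) the larger, and both lie within the scatter. Compound 4 `CC(C)(O)CCNC(=O)c1ccc(C#Cc2cccc(F)c2)cn1` differs from compound 3 at one place: 3-hydroxy-3-methylbutyl in place of 1-(hydroxymethyl)-1-methylethyl on an amide-type nitrogen. Among the compounds with values here, the steps that bear on this are the three exchanges of the group on the amide-type nitrogen, a number 7.8 percentage points lower from compound 1 to compound 2 (within the scatter), a number 5.1 percentage points lower from compound 1 to compound 3 (within the scatter) and a number 2.7 percentage points higher from compound 2 to compound 3 (within the scatter), none beyond the scatter. The expectation for compound 4 is therefore no step beyond the scatter in this assay, in either direction. Compound 4 is estimated at 61% (range 50% to 72%). The expected step is a number 0.1 percentage points higher from compound 3 to compound 4 (within the scatter).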

Compound 4, largest response reached (reported as efficacy), in percent of the reference or control that the assay uses: 61.9%
For compound 4 the middle estimate is 0.9 percentage points below the measured one; the measured number falls inside the stated range.
By their numbers in this assay, from the lowest: compounds 2, 3, 4 and 1 (each within the scatter of the next).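

In this assay, 3-hydroxy-3-methylbutyl on the amide-type nitrogen gives a number 1 percentage points higher from compound 3 to compound 4 (within the scatter) against 1-(hydroxymethyl)-1-methylethyl. Against the groups without a hydroxyl, the result is a number 3.7 percentage points higher from compound 2 to compound 4 (within the scatter) and also a number 4.1 percentage points lower from compound 1 to compound 4 (within the scatter), so all four groups on this nitrogen remain inseparable on this read-out. No supporting data offer an explanation for this flat result.

On these data alone, whether an amine or a carboxylic acid at the end of this chain would produce a step beyond the scatter remains open. The same holds for a longer chain or a piperidine ring on this nitrogen.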